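This account rests on a few compounds, and the source may have more. Where it says the series, first, only, none or still open, it means among the compounds named here.

Compounds measured in an ADME assay on the whole organism (plasma, Mus musculus) for pharmacokinetics, read by LC-MS, at a dose of 30 mg/kg by the oral route; on this read-out higher numbers stand for higher exposure at the dose given and lower numbers for lower exposure:
compound 1 `NCc1cc(Oc2cccc(C(=O)NCCS(N)(=O)=O)c2)nc(C(F)(F)F)c1` gives 1040 nM;
compound 3 `NCc1cc(Oc2cccc(C(=O)N3CC[C@@H](N)C3)c2)nc(C(F)(F)F)c1` gives 670 nM;
for compound 2 `NCc1cc(Oc2cccc(Oc3ccccc3)c2)nc(C(F)(F)F)c1` the result in this assay is "not determined" (no result reported).

Within the data shown here, compound 3 stands lowest of the two numbers, but its only neighbour is compound 1, and the step of a 1.6-fold lower number from compound 1 to compound 3 (0.19 log units; within the scatter) lies within the scatter, so the two are not separable. Compound 4 `CONC(=O)c1cccc(Oc2cc(CN)cc(C(F)(F)F)n2)c1` differs from compound 3 by methoxyamino in place of 3-aminopyrrolidin-1-yl on a carbonyl carbon. Among the measured compounds shown here, the one measured step at this carbonyl carbon, a 1.6-fold lower number from compound 1 to compound 3 (0.19 log units; within the scatter), changed little despite a large swap of groups, so this assay appears tolerant of what is attached there. Compound 4 is therefore expected to show no step beyond the scatter, a 1.3-fold higher number from compound 3 to compound 4 (0.10 log units; within the scatter), with an estimate of 850 nM and a range from 300 nM to 2500 nM.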

Compound 4, maximal plasma concentration: 630 nM
Compound 4: the middle estimate sits 1.3-fold (0.13 log units) above what was measured, and the stated range covers the measured number.
By their numbers in this assay, from the lowest: compounds 4, 3 and 1 (each within the scatter of the next).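

In this assay, methoxyamino in place of 3-aminopyrrolidin-1-yl on the carbonyl carbon gives no separable change (a 1.1-fold lower number from compound 3 to compound 4 (0.03 log units; within the scatter)), and methoxy in place of 2-sulfamoylethyl on the amide-type nitrogen gives none either (a 1.7-fold lower number from compound 1 to compound 4 (0.22 log units; within the scatter)). A small open-chain group with no ring and no stereocentre therefore cannot be told apart from the two larger groups at this position. No measurement shown offers any explanation for this flat result. Still open, going by these compounds, is whether a carboxylic acid or a longer carbon chain on this carbonyl carbon would also stay within the scatter.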